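Swapping the side group on the shared core

A few compounds are considered here, and "the series" means these few. Any claim that something is new, unique, unknown or untested is made for them only; others in the source may bear on it.

compound 1 `CC(=O)OC/C1=C/C[C@](C)(CCC=C(C)C)/C=C/[C@@H](OC(=O)C=C(C)C)[C@](C)(O)/C=C/C1=O`: 2950 nM
compound 2 `CC[Si](CC)(CC)C/C1=C/C[C@](C)(CCC=C(C)C)/C=C/[C@@H](OC(=O)C=C(C)C)[C@](C)(O)/C=C/C1=O`: 3100 nM

In a functional assay on A549 cells (Homo sapiens) for antiproliferative activity, read by MTT assay, with a stated time of 48 h (on this read-out lower numbers stand for stronger inhibition and higher numbers for weaker inhibition), compound 1 and compound 2 lie within the scatter of each other, with compound 2 at 3100 nM. Compound 3 `CC(C)=CCC[C@]1(C)/C=C/[C@@H](OC(=O)C=C(C)C)[C@](C)(O)/C=C/C(=O)/C(Cn2cc(CO)nn2)=C\C1` carries 4-(hydroxymethyl)-1H-1,2,3-triazol-1-yl on a saturated chain carbon bound to a double-bonded ring carbon: a group of 7 heavy atoms (3 carbon, 3 nitrogen, 1 oxygen; one five-membered aromatic ring with 3 hetero atoms) in place of a group of 7 heavy atoms (6 carbon, 1 silicon; no ring), on a saturated chain carbon bound to a double-bonded ring carbon. Going by the values given here, one measured step bears on this place, a 1.1-fold higher number from compound 1 to compound 2 (0.02 log units; within the scatter), and it exchanges two groups without a ring. On that evidence, no step beyond the scatter is expected in this assay, and no direction can be favoured. Among the compounds with values here, no measured compound carries a ring at this place, so the expected range stays wide. The expected step is a 1.0-fold lower number from compound 2 to compound 3 (0.01 log units; within the scatter). Compound 3 is estimated at 3000 nM, with an expected range from 1000 nM to 9000 nM.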

Compound 3, half-maximal inhibitory concentration: 3470 nM
For compound 3 the middle estimate is 1.2-fold (0.06 log units) below the measured one; low and high end bracket the measured number.
By their numbers in this assay, from the lowest: compounds 1, 2 and 3 (each within the scatter of the next).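

Going by these compounds alone, at this place, on a saturated chain carbon bound to a double-bonded ring carbon, a ring now appears for the first time: in this assay, 4-(hydroxymethyl)-1H-1,2,3-triazol-1-yl gives a 1.1-fold higher number from compound 2 to compound 3 (0.05 log units; within the scatter) and, set against acetoxy, a 1.2-fold higher number from compound 1 to compound 3 (0.07 log units; within the scatter). The entering group brings a five-membered aromatic ring and a hydrogen-bond donor, neither of which the group leaving from compound 2 has, yet neither step leaves the scatter, and this read-out does not separate the three groups tried here. No measurement at hand accounts for this flat result.

Going by these compounds, it remains open whether an amine, a carboxylic acid or a longer chain at this place would move the number beyond the scatter. The compounds shown vary only this one place, and the contribution of the rest of the shared core remains untested by them.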